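Swapping Phenyl for 1H-Indol-6-yl in a Small Series

The compounds below may be only part of what the source reports. "The series", "measured", "known", "first", "only" and "open" are said of these compounds alone.

In a functional assay on A549 cells (Homo sapiens) for inhibition, read by CCK-8 assay, with a stated time of 48 h (on this read-out lower numbers stand for stronger inhibition and higher numbers for weaker inhibition), three compounds sharing one core have been measured. Compound 1 `COc1cc(-c2ccnc3cc(-c4ccc(Cl)cc4)nn23)cc(OC)c1OC`, with chloro on the phenyl ring, gives 3070 nM. Compound 2 `COc1cc(-c2ccnc3cc(-c4ccc(C)cc4)nn23)cc(OC)c1OC`, with methyl there, gives 3 nM. Compound 3 `COc1cc(-c2ccnc3cc(-c4ccccc4)nn23)cc(OC)c1OC`, with plain phenyl, gives 208 nM, which places it between the other two.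

The next structure is compound 4 `COc1cc(-c2ccnc3cc(-c4ccc5cc[nH]c5c4)nn23)cc(OC)c1OC`, with 1H-indol-6-yl in place of phenyl on an aromatic carbon of a five-membered aromatic ring with 2 nitrogen: 1H-indol-6-yl in place of phenyl on an aromatic carbon. For the measured compounds named here, no measured compound carries this group, so the known steps bear on it only indirectly. All of them are changes on that same phenyl ring, and all are large: a 69-fold higher number from compound 2 to compound 3 (1.84 log units; beyond the scatter), a 15-fold lower number from compound 1 to compound 3 (1.17 log units; beyond the scatter) and a 1000-fold lower number from compound 1 to compound 2 (3.01 log units; beyond the scatter). The number therefore responds strongly to small changes here, but not in one direction, since compound 1 goes against any rule that a substituent lowers it. A large step is thus expected rather than none, and a lower number is favoured only weakly, on the precedent of compound 2 at 3 nM. The expected change is an 8.3-fold lower number from compound 3 to compound 4 (0.92 log units; beyond the scatter). Compound 4 is estimated at 25 nM, with an expected range from 2 nM to 250 nM.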

Compound 4, half-maximal inhibitory concentration: 170 nM
Beside the measured number, compound 4's estimate is 6.8-fold (0.83 log units) below it, and the stated range covers the measured number.
By their numbers in this assay, from the lowest: compound 2; then compounds 4 and 3 (each within the scatter of the next); then compound 1.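

In this assay, 1H-indol-6-yl in place of phenyl brings an added five-membered aromatic ring with 1 hetero atom and a hydrogen-bond donor, yet the values stay level, with a 1.2-fold lower number from compound 3 to compound 4 (0.09 log units; within the scatter). For the compounds shown here, this position therefore tolerates a fused two-ring group, which the earlier compounds, all of them single phenyl rings, could not show, but that group does not reach the value given by 4-methylphenyl, with a 57-fold higher number from compound 2 to compound 4 (1.75 log units; beyond the scatter), and it remains well clear of 4-chlorophenyl, with an 18-fold lower number from compound 1 to compound 4 (1.26 log units; beyond the scatter). Nothing available explains why the indole group matches plain phenyl and not 4-methylphenyl.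

The compounds shown leave open whether the hydrogen on the indole nitrogen matters at all, which an indole carrying a methyl group on that nitrogen would test. They also leave open whether the low value of compound 2 is specific to methyl or extends to an ethyl group or a methoxy group in its place, and a basic amine on the phenyl ring is equally unexplored.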